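Swapping the Ether Group on Compound 1

The source may hold more compounds than are shown below. What is called first, only, known or untested is meant among the compounds shown, and "the series" means these compounds.

Going by the values given here, the two compounds measured so far share a core and differ in what hangs from it. Compound 1 `C1=C(c2cncc(OCc3ccccc3)c2)CC2CNCC1C2` carries a benzyl group on an oxygen of its aromatic ring; compound 2 `C1=C(c2ccncc2)CC2CNCC1C2` lacks such a group. In an in vitro assay on SH-EP1 cells for displacement of a labelled ligand from Neuronal acetylcholine receptor; alpha4/beta2 (Homo sapiens) (a higher number here means a weaker inhibitor, a lower number a stronger inhibitor), compound 1 gives 0.7 nM, and compound 2 gives 56 nM. Compound 1 thus has the lower of the two numbers, and its gap to compound 2 lies well beyond the usual scatter.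

Compound 3 `COc1ccc(Oc2cncc(C3=CC4CNCC(C3)C4)c2)cc1` keeps the core of compound 1 and changes only the group on that oxygen: 4-methoxyphenyl in place of benzyl on an oxygen on an aromatic ring. Among the compounds with values here, no measured pair shows this exchange, so the expectation rests on compound 1 alone. Because compound 1 gives 0.7 nM in this assay, compound 3 is expected to stay a strong inhibitor. The expected step of a 2.9-fold higher number from compound 1 to compound 3 (0.46 log units; beyond the scatter) is a small rise that may sit within the scatter. Compound 3 is estimated at 2 nM, in a range from 0.5 nM to 10 nM.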

Compound 3, inhibition constant: 1.4 nM
Compound 3: the middle estimate sits 1.4-fold (0.15 log units) above what was measured; the measured number falls inside the stated range.
By their numbers in this assay, from the lowest: compounds 1 and 3 (each within the scatter of the next); then compound 2.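

At this position, on an oxygen on an aromatic ring, 4-methoxyphenyl can take the place of benzyl with a 2.0-fold higher number from compound 1 to compound 3 (0.30 log units; within the scatter) in this assay. The earlier compounds shown here did not show this: the group that enters has 8 heavy atoms against 7 and brings 1 hydrogen-bond acceptor where benzyl has 0, yet compound 3 stays within the scatter of compound 1, so this exchange leaves the strong binding in place. Nothing available explains why the two groups give such close numbers.

As far as these compounds go, what remains open is how far this tolerance extends beyond these two aromatic groups. A plain phenyl would separate the methoxy from the rest of the group, while a small methyl or a carboxylic acid on the ring would test much different groups at this position.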